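The source may report more compounds than this note shows. Statements on the series, on what has been measured and on what is new or still open speak of the compounds shown alone.

Among the measured compounds shown here, compound 1, with the structure `CN1C(=O)C2=C(C1=O)N(CC(=O)Nc1ccc(-c3ccncc3)cc1)CCC2`, is one of two compounds measured in an assay on cells for inhibition of Protein-serine O-palmitoleoyltransferase porcupine (Homo sapiens), read by reporter gene assay (a higher number here means a weaker inhibitor, a lower number a stronger inhibitor), where compound 1 gives 72 nM. This is the higher of the two numbers. The other measured compound, compound 2, has the structure `Cc1ccc(-c2ccc(NC(=O)CN3CCCC4=C3C(=O)N(C3CC3)C4=O)nn2)cn1` and in this assay compound 2 gives 12 nM, a lower number lying well beyond the usual scatter. Since compound 2 differs from compound 1 in several parts of the molecule at once, nothing can be read from this pair about any single change.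

Compound 3, with the structure `CN1C(=O)C2=C(C1=O)N(CC(=O)Nc1ccc(-c3ccccc3)cc1)CCC2`, has not yet been measured. It differs from compound 1 in one place: phenyl in place of pyridin-4-yl on an aromatic carbon. For the measured compounds named here, no measured pair shows this exact change, so the expectation for compound 3 rests on the value of compound 1 alone and carries a wide range. The step from compound 1 to compound 3 in this assay is expected to be a moderate weakening, a 3.5-fold higher number from compound 1 to compound 3 (0.54 log units; beyond the scatter), though a result within the scatter cannot be ruled out. Compound 3 is therefore estimated to give 250 nM in this assay, within a range of 70 nM to 900 nM.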

Compound 3, half-maximal inhibitory concentration: 12 nM
Compound 3: middle estimate off by 21-fold (1.32 log units), on the high side; the measured number lies below the stated range.
By their numbers in this assay, from the lowest: compounds 2 and 3 (each within the scatter of the next); then compound 1.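

In this assay, placing phenyl in place of pyridin-4-yl, on an aromatic carbon para to a large group, gives a 6.0-fold lower number from compound 1 to compound 3 (0.78 log units; beyond the scatter). Compound 1 and compound 3 differ only in this group, so the comparison isolates one change in a way that the pair of compound 1 and compound 2 could not, and it shows that on the core of compound 1 this position does not need the ring nitrogen, or the hydrogen-bond acceptor counted with it, to reach the lower number. Nothing available here explains why removing that nitrogen goes with a stronger inhibitor.

Among the compounds shown here, with only two groups compared at this position, it remains open whether the nitrogen matters in itself or whether other groups would fit as well, such as pyridin-3-yl, a fluorophenyl or a methoxyphenyl. Going by these compounds, it also remains open whether the same exchange would give a step of similar size in a compound carrying other changes, such as cyclopropyl in place of the methyl on the core of compound 1, as seen in compound 2.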